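This account rests on a few compounds, and the source may have more. Where it says the series, first, only, none or still open, it means among the compounds named here.

In an in vivo functional assay on the whole organism for inhibition, with Rattus norvegicus as the target (on this read-out higher numbers stand for an effect only at larger amounts of compound and lower numbers for an effect already at smaller amounts), compound 1 (`CCCCc1nc(C)c(CC(=O)N2CCOCC2)c(=O)n1Cc1ccc(-c2ccccc2-c2nnn[nH]2)cc1`) gives 0.018 mg/kg and compound 2 (`CCCCc1nc(C)c(CCC(=O)N2CCC[C@H]2C(=O)OC)c(=O)n1Cc1ccc(-c2ccccc2-c2nnn[nH]2)cc1`) gives 0.063 mg/kg here, so compound 2 holds the higher of the two numbers. The unmeasured compound 3 (`CCCCc1nc(C)c(CCC(=O)N2CCSCC2)c(=O)n1Cc1ccc(-c2ccccc2-c2nnn[nH]2)cc1`) keeps the shared core and changes only the group on a carbonyl carbon, with thiomorpholin-4-yl in place of 2-(methoxycarbonyl)pyrrolidin-1-yl (thiomorpholin-4-yl in place of 2-(methoxycarbonyl)pyrrolidin-1-yl on a carbonyl carbon). Within the data shown here, only one measured step bears on this change. It shows a 3.5-fold higher number from compound 1 to compound 2 (0.54 log units; beyond the scatter) on going from (morpholin-4-yl)carbonyl to ((2-(methoxycarbonyl)pyrrolidin-1-yl)carbonyl)methyl. Compound 3 keeps the methyl part of that larger group, but its six-membered non-aromatic ring matches the ring type of the morpholin-4-yl in compound 1. Among the measured compounds shown here, it may therefore win back part of that step, though not necessarily all of it, and no compound measured so far carries thiomorpholin-4-yl. The estimated step is a 1.8-fold lower number from compound 2 to compound 3 (0.26 log units; within the scatter) and a larger shift is not expected from this single guide. For compound 3 the expected value is 0.035 mg/kg on this estimate. The expected range for compound 3 runs from 0.012 mg/kg to 0.1 mg/kg in this read-out.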

Compound 3, dose for half-maximal effect: 0.204 mg/kg
Compound 3: the middle estimate sits 5.8-fold (0.77 log units) below what was measured; the whole stated range lies below it.
By their numbers in this assay, from the lowest: compound 1; then compound 2; then compound 3.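

In this assay thiomorpholin-4-yl on the carbonyl carbon gives a higher number than 2-(methoxycarbonyl)pyrrolidin-1-yl (a 3.2-fold higher number from compound 2 to compound 3 (0.51 log units; beyond the scatter)), so a six-membered non-aromatic ring in this place does not by itself bring the number back towards that of compound 1. The group that leaves is the larger of the two, with more heavy atoms and a defined stereocentre, so in this pair the number does not simply rise with the size of the group. The gap to compound 1 is now the widest among the three compounds (an 11-fold higher number from compound 1 to compound 3 (1.05 log units; beyond the scatter)), and this step combines the longer chain with the change from morpholin-4-yl to thiomorpholin-4-yl.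

Nothing available gives a reason for these shifts. Still open, on these data alone, is how much of that wider gap belongs to the chain and how much to the sulfur in the ring, which morpholin-4-yl on the longer chain or thiomorpholin-4-yl on the shorter one would separate, and where piperidin-1-yl, or a carboxylic acid in place of the methoxycarbonyl, would fall.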